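A few compounds are considered here, and "the series" means these few. Any claim that something is new, unique, unknown or untested is made for them only; others in the source may bear on it.

Measured compounds:
- compound 1 `Nc1ccc(-c2cn(Cc3cc(C(=O)O)cc(-c4ccc(C(=O)O)cc4)c3)nn2)cc1` — in an assay on cells for inhibition of ubiquitin carboxyl-terminal hydrolase isozyme L5 (Homo sapiens), read by fluorescence, with a stated time of 30 min (a lower number here means a stronger inhibitor, a higher number a weaker inhibitor), compound 1 gives 285000 nM
- compound 2 `CC(C(=O)O)c1ccc(C(=O)c2cccc(-c3occc3C(=O)O)c2)s1` — in this assay compound 2 gives 75700 nM

Compound 2 holds the lower of the two numbers. Its nearest neighbour is compound 1, whose number stands above that of compound 2 by a gap beyond the usual scatter, so compound 2 is the stronger of the pair on this evidence. Among the compounds with values here, the two compounds share no common core, so no single-point step between them is available.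

Compound 3 `CC(C(=O)O)c1ccc(C(=O)c2cccc(-c3ccccc3C(=O)O)c2)s1` is the next compound to be measured in this assay. It differs from compound 2 by 2-carboxyphenyl in place of 3-carboxyfuran-2-yl on an aromatic carbon. This exchange keeps the carboxylic acid and replaces one aromatic ring by another at the same position; the rest of the molecule is unchanged. Within the data shown here, no measured pair shows this kind of swap, so no step size can be read from the data. The expectation is a step from compound 2 to compound 3 that stays within or close to the scatter, with no strong direction. Compound 3 is estimated at 85000 nM, with a range of 25000 nM to 280000 nM, which means an expected step of a 1.1-fold higher number from compound 2 to compound 3 (0.05 log units; within the scatter).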

Compound 3, half-maximal inhibitory concentration: 89100 nM
Compound 3: middle estimate off by 1.0-fold (0.02 log units), on the low side; the measured number falls inside the stated range.
By their numbers in this assay, from the lowest: compounds 2 and 3 (each within the scatter of the next); then compound 1.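

In this assay, within the data shown here, 2-carboxyphenyl in place of 3-carboxyfuran-2-yl, on an aromatic carbon of a six-membered aromatic ring of carbon only and meta to a large group, gives a 1.2-fold higher number from compound 2 to compound 3 (0.07 log units; within the scatter), the only single-point step available so far. With the carboxylic acid kept, this position therefore accepts either a five-membered aromatic ring with 1 hetero atom or a six-membered aromatic ring of carbon only without a change beyond the scatter, although this rests on one pair and steps involving compound 1 cannot be read. No measured information on the origin of this flat step is available.

The compounds shown leave open how much the carboxylic acid on the exchanged ring contributes, as both compounds carry it; a methyl ester, a primary amide or a plain phenyl at this position would address that. As far as these compounds go, the role of the second carboxylic acid, on the part shared by compound 2 and compound 3, is also open, and a hydroxymethyl group in its place would test it.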